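Swapping methyl for chloro on the aryl group of compound 3

The source may report more compounds than this note shows. Statements on the series, on what has been measured and on what is new or still open speak of the compounds shown alone.

Measured so far:
compound 1, `Cc1nn(-c2nc(-c3ccc(Cl)c(Cl)c3)c(SC(C)C)s2)c(C(=O)O)c1-c1cncnc1`, 22000 nM
compound 2, `Cc1cc(C#N)cc(-c2c(C)nn(-c3nc(-c4ccc(Cl)c(Cl)c4)c(SC(C)C)s3)c2C(=O)O)c1`, 4800 nM
compound 3, `Cc1cccc(-c2c(C)nn(-c3nc(-c4ccc(Cl)c(Cl)c4)c(SC(C)C)s3)c2C(=O)O)c1`, 17000 nM

These three share one core and differ only in the aryl group attached to it. In a functional assay on BJAB cells (Homo sapiens) for antiproliferative activity, with a stated time of 4 days (on this read-out lower numbers stand for an effect already at smaller amounts and higher numbers for an effect only at larger amounts of compound), compound 3 gives 17000 nM, the second highest of the three numbers: it sits close to compound 1, as a 1.3-fold lower number from compound 1 to compound 3 (0.11 log units; within the scatter) shows, and it is clearly apart from compound 2, see a 3.5-fold higher number from compound 2 to compound 3 (0.55 log units; beyond the scatter). Compound 4, `Cc1nn(-c2nc(-c3ccc(Cl)c(Cl)c3)c(SC(C)C)s2)c(C(=O)O)c1-c1cccc(Cl)c1`, is not yet measured. It differs from compound 3 in one place: chloro in place of methyl on an aromatic carbon. Among the measured compounds shown here, no measured step swaps methyl for chloro; the two steps that touch this ring, a 1.3-fold lower number from compound 1 to compound 3 (0.11 log units; within the scatter) and a 3.5-fold higher number from compound 2 to compound 3 (0.55 log units; beyond the scatter), change other groups, and only the cyano one moved the number beyond the scatter. A one-atom swap of this kind is therefore expected to give a step within the scatter, a 1.1-fold lower number from compound 3 to compound 4 (0.05 log units; within the scatter), with no clear direction. Compound 4 is estimated at 15000 nM, between 6000 nM and 40000 nM.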

Compound 4, half-maximal effective concentration: 13600 nM
Beside the measured number, compound 4's estimate is 1.1-fold (0.04 log units) above it; low and high end bracket the measured number.
By their numbers in this assay, from the lowest: compound 2; then compounds 4, 3 and 1 (each within the scatter of the next).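

In this assay, among the compounds shown here, this is the first direct swap of methyl for chloro on this six-membered aromatic ring, and a 1.3-fold lower number from compound 3 to compound 4 (0.10 log units; within the scatter) leaves the two groups indistinguishable. The 3-chlorophenyl group also stays within the scatter of pyrimidin-5-yl, with a 1.6-fold lower number from compound 1 to compound 4 (0.21 log units; within the scatter) as the step, so three different aryl groups now give similar numbers, while the 3-cyano-5-methylphenyl group of compound 2 stands apart from all of them, here through a 2.8-fold higher number from compound 2 to compound 4 (0.45 log units; beyond the scatter) as the step. Nothing measured here bears on what lies behind these numbers.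

From the compounds shown here alone, what a 3-cyanophenyl group without the methyl would give remains open. So does the effect of an amine or a carboxylic acid on this ring, and whether any such group would bring the number much lower.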